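Inverting one ring stereocentre of compound 1

The compounds below may be only part of what the source reports. "The series", "measured", "known", "first", "only" and "open" are said of these compounds alone.

Compound 1 `O=C(N1C[C@@H](O)C=C[C@@H]1Cc1ccccc1)n1ncc(C(O)(c2ccc(F)cc2)c2ccc(F)cc2)n1` gives 20 nM in an assay on HEK-293T cells for inhibition of diacylglycerol lipase-alpha (Homo sapiens), read by colorimetric assay (on this read-out higher numbers stand for weaker inhibition and lower numbers for stronger inhibition), the highest number among the three measured compounds. Compound 2 `COc1cccc(CC2CCCCN2C(=O)n2ncc(C(O)(c3ccc(F)cc3)c3ccc(F)cc3)n2)c1` gives 3.16 nM in this assay, and compound 3 `O=C(N1CCCCC1Cc1ccccc1)n1ncc(C(O)(c2ccc(F)cc2)c2ccc(F)cc2)n1` gives 1 nM, so compound 1 stands beyond the scatter above both of them. Within the data shown here, the only single-point step measured so far, a 3.2-fold lower number from compound 2 to compound 3 (0.50 log units; beyond the scatter), concerns hydrogen in place of methoxy on an aromatic carbon and says nothing about a change of configuration.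

Compound 4 `O=C(N1C[C@H](O)C=C[C@@H]1Cc1ccccc1)n1ncc(C(O)(c2ccc(F)cc2)c2ccc(F)cc2)n1` is the next compound. the two compounds have the same atoms and bonds and differ only in configuration as drawn: 1 of 2 stereo elements differ; a stereocentre at a saturated ring carbon is drawn S in compound 1 and R in compound 4 The stereocentre at a saturated ring carbon is thus inverted while every atom and bond stays in place. Among the measured compounds shown here, no measured pair differs only in configuration, so nothing here shows how this assay responds to such an inversion, and the direction cannot be read from the data. The expected step in this assay is a 1.5-fold higher number from compound 1 to compound 4 (0.18 log units; within the scatter), no change beyond the scatter, with wide uncertainty on either side. Compound 4 is estimated at 30 nM, with a range from 6 nM to 150 nM.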

Compound 4, half-maximal inhibitory concentration: 12.6 nM
Beside the measured number, compound 4's estimate is 2.4-fold (0.38 log units) above it, and the stated range covers the measured number.
By their numbers in this assay, from the lowest: compound 3; then compound 2; then compounds 4 and 1 (each within the scatter of the next).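

Inverting the stereocentre at this saturated ring carbon gives, in this assay, a 1.6-fold lower number from compound 1 to compound 4 (0.20 log units; within the scatter). Among these compounds, this is the first measured pair that isolates configuration, and at this position the read-out does not separate the S and R forms: the fact that compounds 1 and 4 differ only in the configuration as drawn. The finding holds only for this one position, with the second stereo element kept as drawn and every atom and bond of the core in place.

Still open, on these data alone, is what the second stereo element contributes, since compound 1 and compound 4 share it, so the effect of inverting that centre cannot be read from this pair. Also open, as far as these compounds go, is whether configuration at the saturated ring carbon stays this unimportant with another group there, such as an amine or a carboxylic acid.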